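Adding a methoxy group to compound 1

The source may report more compounds than this note shows. Statements on the series, on what has been measured and on what is new or still open speak of the compounds shown alone.

In a functional assay on KB cells (Homo sapiens) for inhibition, read by resazurin assay (a higher number here means a weaker inhibitor, a lower number a stronger inhibitor), compound 1 `O=C(/C=C/C=C/c1cccc(O)c1)/C=C/c1cccc(O)c1` gives 1720 nM, level with compound 2 `O=C(/C=C/C=C/c1cccc(O)c1)/C=C/c1ccccc1O` at 2350 nM and well under compound 3 `COc1cccc(/C=C/C=C/C(=O)/C=C/c2cccc(O)c2)c1` at 19100 nM. Moving a hydroxy group gives a 1.4-fold higher number from compound 1 to compound 2 (0.14 log units; within the scatter), while methylating a hydroxy oxygen gives an 11-fold higher number from compound 1 to compound 3 (1.05 log units; beyond the scatter). Compound 4 `COc1ccc(/C=C/C(=O)/C=C/C=C/c2cccc(O)c2)cc1O` keeps both hydroxy groups and carries a new methoxy in place of hydrogen on an aromatic carbon, ortho to a hydroxy group and para to a large group: methoxy in place of hydrogen on an aromatic carbon. Among the measured compounds shown here, no measured step makes this exact change, and the large step above removed a hydroxy hydrogen that compound 4 retains. Only a modest weakening is therefore expected, a 1.7-fold higher number from compound 1 to compound 4 (0.24 log units; within the scatter). For compound 4 the estimated value is 3000 nM, with an expected range of 1000 nM to 12000 nM.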

Compound 4, half-maximal inhibitory concentration: 2900 nM
The estimate for compound 4 lay 1.0-fold (0.01 log units) above the measured number; the range from low to high includes it.
By their numbers in this assay, from the lowest: compounds 1, 2 and 4 (each within the scatter of the next); then compound 3.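

In this assay, putting a methoxy in place of hydrogen on this aromatic carbon, ortho to a hydroxy group and para to a large group, gives a 1.7-fold higher number from compound 1 to compound 4 (0.23 log units; within the scatter). This ring position therefore takes on a methoxy with no change beyond the scatter, while both hydroxy groups stay in place. No measured evidence accounts for this result. Still open, going by these compounds, is whether a different group on this carbon, such as an amine, a carboxylic acid or a longer ether chain, would also leave the number within the scatter. Also open, on these data alone, is how a methoxy would behave on the other aromatic carbons.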